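A few compounds are considered here, and "the series" means these few. Any claim that something is new, unique, unknown or untested is made for them only; others in the source may bear on it.

Values measured in a functional assay on a cell-free system (plasma, Homo sapiens), with a stated time of 3 min (on this read-out lower numbers stand for stronger inhibition and higher numbers for weaker inhibition), are as follows

- compound 1 `O=C(NCc1cc(Cl)ccc1-n1cnnn1)[C@@H]1CC=NN1C(=O)[C@H](O)Cc1ccccc1` gives 1400 nM
- compound 2 `O=C(NCc1cc(Cl)ccc1-n1cnnn1)[C@@H]1C[C@H]2C[C@H]2N1C(=O)[C@H](O)c1ccccc1` gives 680 nM
- compound 3 `CC(C)(C)[C@@H](O)C(=O)N1NCC[C@H]1C(=O)NCc1cc(Cl)ccc1-n1cnnn1` gives 1700 nM

The value of compound 1 lies within the scatter of that of compound 3, whereas compound 2 has a lower number, with the gap to compound 1 beyond the scatter. Compound 4 `O=C(NCc1cc(Cl)ccc1-n1cnnn1)[C@@H]1CC=NN1C(=O)[C@H](O)C1CCCCC1` has not yet been measured. It carries cyclohexyl in place of benzyl on a saturated chain carbon bound to a carbonyl carbon and an oxygen on a saturated carbon. Going by the values given here, no two measured compounds differ in only one place, so the data offer no direct precedent for this change. A small shift toward stronger inhibition is expected, and it would probably stay within the scatter. The expected step is a 1.6-fold lower number from compound 1 to compound 4 (0.19 log units; within the scatter). For compound 4 the estimated value is 900 nM, with an expected range from 300 nM to 2500 nM.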

Compound 4, half-maximal inhibitory concentration: 970 nM
The estimate for compound 4 lay 1.1-fold (0.03 log units) below the measured number; the range from low to high includes it.
By their numbers in this assay, from the lowest: compounds 2, 4, 1 and 3 (each within the scatter of the next, the first and the last beyond it).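

In this assay, the first comparison differing in one place is a 1.4-fold lower number from compound 1 to compound 4 (0.16 log units; within the scatter) on replacing benzyl with cyclohexyl. On this saturated chain carbon bound to a carbonyl carbon and an oxygen on a saturated carbon, a six-membered aromatic ring of carbon only can thus give way to a six-membered non-aromatic ring of carbon only without a change beyond the scatter. No supporting data bear on this result. The compounds shown leave open how an amine or a carboxylic acid in place of cyclohexyl would read in this assay. They also leave open whether a longer chain at this position would keep the number within the scatter.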